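The source may hold more compounds than are shown below. What is called first, only, known or untested is meant among the compounds shown, and "the series" means these compounds.

Compound 1 `CCOC(=O)/C=C/c1ccncc1-c1ccc2c(cnn2C)c1`: 1330 nM
Compound 2 `O=C(O)CCNC(=O)/C=C/c1ccncc1-c1ccc2ccccc2c1`: "not determined" (no result reported)
Compound 3 `CNC(=O)/C=C/c1ccncc1-c1ccc2cnn(C)c2c1`: "not determined" (no result reported)

Going by the values given here, in a functional assay on HCT-116 cells (Homo sapiens) for inhibition, read by MTT assay, with a stated time of 72 h (on this read-out higher numbers stand for weaker inhibition of growth and lower numbers for stronger inhibition of growth), compound 1 gives 1330 nM, the only number available, so it cannot yet be ranked against anything. Compound 2 and compound 3 have no result to compare. Compound 4 `CNC(=O)/C=C/c1ccncc1-c1ccc2c(cnn2C)c1` keeps the core of compound 1 and changes one group, with methylamino in place of ethoxy on a carbonyl carbon. Among the compounds with values here, no measured pair shows this change, so the expectation starts from compound 1 at 1330 nM and carries wide uncertainty. A modest rise in the number, meaning weaker inhibition of growth, is expected, estimated as a 1.7-fold higher number from compound 1 to compound 4 (0.22 log units; within the scatter). The estimate for compound 4 is 2200 nM, with an expected range from 500 nM to 9000 nM.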

Compound 4, concentration for 50% growth inhibition: 3480 nM
The estimate for compound 4 lay 1.6-fold (0.20 log units) below the measured number; low and high end bracket the measured number.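

In this assay, going by these compounds alone, methylamino in place of ethoxy on a carbonyl carbon gives a 2.6-fold higher number from compound 1 to compound 4 (0.42 log units; beyond the scatter) and so the first readable comparison at this position. The step is modest but lies beyond the usual scatter, so growth inhibition here does respond to the group on this carbonyl carbon, and the methylcarbamoyl form is the weaker of the two. No measurement at hand gives a reason for this shift. Still open, as far as these compounds go, is whether dimethylamino or a longer chain such as propylamino on the same carbonyl carbon would raise the number further or bring it back down.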